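A few compounds are considered here, and "the series" means these few. Any claim that something is new, unique, unknown or untested is made for them only; others in the source may bear on it.

Measured so far:
compound 1, `COc1cc(/C=C/C(=O)c2cccc(-n3cc(-c4ccccc4)[nH]c3=O)c2)ccc1O`, in a functional assay on NCI-H23 cells (Homo sapiens) for inhibition; on this read-out higher numbers stand for weaker inhibition of growth and lower numbers for stronger inhibition of growth: 2020 nM
compound 2, `O=C(/C=C/c1cccc(O)c1)c1cccc(-n2cc(-c3ccccc3)[nH]c2=O)c1`, in this assay: 3350 nM

Two compounds with the shared core are in hand. Within the data shown here, the only step between them, a 1.7-fold higher number from compound 1 to compound 2 (0.22 log units; within the scatter), stays within the scatter, so the two numbers of compound 1 and compound 2 cannot be ordered; compound 2 simply stands within the scatter of compound 1 in this assay.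

Compound 3, `O=C(/C=C/c1cccc(O)c1)c1cccc(-n2cc(-c3ccc(Cl)cc3)[nH]c2=O)c1`, is not yet measured. Relative to compound 2 the change is chloro in place of hydrogen on an aromatic carbon. Among the measured compounds shown here, no measured step touches this ring: the one step in hand alters the hydroxyphenyl end of the chain, not the phenyl on the core, so it gives no guidance on direction. With nothing pointing either way, the step from compound 2 to compound 3 is expected to stay within the scatter, a 1.1-fold lower number from compound 2 to compound 3 (0.05 log units; within the scatter). Compound 3 is therefore estimated in this assay at 3000 nM, with a range of 1200 nM to 8000 nM. For the measured compounds named here, the range is set wide: the single step in hand, a 1.7-fold higher number from compound 1 to compound 2 (0.22 log units; within the scatter), concerns a different ring.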

Compound 3, concentration for 50% growth inhibition: 2780 nM
For compound 3 the middle estimate is 1.1-fold (0.03 log units) above the measured one, within the range that was stated.
By their numbers in this assay, from the lowest: compounds 1, 3 and 2 (each within the scatter of the next).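

Among these compounds, this is the first measured change on the phenyl of the shared core, as the earlier step touched only the hydroxyphenyl end of the chain. Going from phenyl to 4-chlorophenyl gives a 1.2-fold lower number from compound 2 to compound 3 (0.08 log units; within the scatter) in this assay, so a single chloro on this aromatic carbon, para to a large group, has no readable effect on the number and no direction can be assigned to it. Nothing at hand accounts for this result.

As far as these compounds go, it remains open whether a different group at this place, such as a carboxylic acid or a dimethylamino group, would move the number beyond the scatter in this assay or not. Also open, from the compounds shown here alone, is whether the same phenyl to 4-chlorophenyl change would read the same alongside the 4-hydroxy-3-methoxyphenyl end of compound 1.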